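Cyano in Place of Methoxy on the Phenyl of Compound 3

A few compounds are considered here, and "the series" means these few. Any claim that something is new, unique, unknown or untested is made for them only; others in the source may bear on it.

Compound 3 `COc1ccc(-c2cc(COC(Cc3cn(C4CCN(Cc5ccc([N+](=O)[O-])cc5)CC4)nn3)c3ccc(Br)cc3)on2)cc1` stands, together with compound 2 `O=[N+]([O-])c1ccc(CN2CCC(n3cc(CC(OCc4cc(-c5ccc(F)cc5)no4)c4ccc(Br)cc4)nn3)CC2)cc1`, at the low end of the three numbers in a functional assay on Huh-7 cells (Homo sapiens) for cytotoxicity, with a stated time of 48 h; on this read-out higher numbers stand for weaker inhibition and lower numbers for stronger inhibition: compound 3 gives 2000 nM, compound 2 gives 2000 nM, and compound 1 `O=[N+]([O-])c1ccc(CN2CCC(n3cc(CC(OCc4cc(-c5ccccc5)no4)c4ccc(Br)cc4)nn3)CC2)cc1` gives 7000 nM. Compound 4 `N#Cc1ccc(-c2cc(COC(Cc3cn(C4CCN(Cc5ccc([N+](=O)[O-])cc5)CC4)nn3)c3ccc(Br)cc3)on2)cc1` differs from compound 3 by cyano in place of methoxy on an aromatic carbon. Among the measured compounds shown here, two measured steps touch that same spot: a 3.5-fold lower number from compound 1 to compound 3 (0.54 log units; beyond the scatter), and no change at the digits printed from compound 2 to compound 3 (within the scatter). Both groups that replaced hydrogen there gave the same number, so swapping one group for another at this position has so far moved nothing. Cyano itself is untested, so little movement is expected: the step of no change at the digits printed from compound 3 to compound 4 (within the scatter) is estimated. Compound 4 is therefore expected to give about 2000 nM, within 800 nM to 5000 nM.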

Compound 4, half-maximal inhibitory concentration: 5000 nM
The estimate for compound 4 lay 2.5-fold (0.40 log units) below the measured number; low and high end bracket the measured number.
By their numbers in this assay, from the lowest: compounds 2 and 3 (each within the scatter of the next); then compounds 4 and 1 (each within the scatter of the next).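

In this assay, this position no longer looks indifferent to the group it carries: cyano breaks the earlier tie between methoxy and fluoro (a 2.5-fold higher number from compound 3 to compound 4 (0.40 log units; beyond the scatter); a 2.5-fold higher number from compound 2 to compound 4 (0.40 log units; beyond the scatter)). Cyano also differs from hydrogen by no more than the scatter (a 1.4-fold lower number from compound 1 to compound 4 (0.15 log units; within the scatter)), whereas methoxy and fluoro each moved the number beyond it. Nothing available here explains this difference between the groups.

From the compounds shown here alone, whether an amine or a carboxylic acid at this spot would behave like cyano or like methoxy remains open. So does whether cyano would have the same effect with other groups elsewhere on the shared core.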